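Bromo for chloro in a series held at a limit

A few compounds are considered here, and "the series" means these few. Any claim that something is new, unique, unknown or untested is made for them only; others in the source may bear on it.

In an ADME assay on HaCaT cells (Homo sapiens) for cytotoxicity, read by MTT assay, with a stated time of 48 h (on this read-out higher numbers stand for weaker inhibition and lower numbers for stronger inhibition), compound 3 (`Fc1ccc(-c2nn(-c3ccccc3)cc2-c2nc3cc(Cl)ccc3[nH]2)cc1`) gives > 50000 nM, which is a limit and not a number. Compound 2 (`Fc1ccc(-c2nn(-c3ccccc3)cc2-c2nc3ccccc3[nH]2)cc1`) gives > 50000 nM, also a limit. Compound 1 (`Brc1ccc2[nH]c(-c3cn(-c4ccccc4)nc3-c3ccccc3)nc2c1`) gives > 50000 nM, again a limit. Compound 3 therefore has no readable position within the series, and all the data stand at the limit of > 50000 nM in this assay, at which 3 of the 3 values shown sit.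

The change to compound 4 (`Fc1ccc(-c2nn(-c3ccccc3)cc2-c2nc3cc(Br)ccc3[nH]2)cc1`) is bromo in place of chloro on an aromatic carbon.

For the measured compounds named here, no measured step exchanges these two groups. The nearest is a step that the two limits leave unreadable from compound 2 to compound 3, where chloro replaces hydrogen on an aromatic carbon, and it gives no size to carry over. Going by the values given here, compound 1 already carries bromo and shows > 50000 nM, a limit, so bromo has not yet been seen to bring a readable value. No step beyond the scatter is therefore expected in this assay, and compound 4 will most likely be reported as a limit again. The expected change is a number no higher from compound 3 to compound 4 (the limit leaves the size open). For compound 4 the estimated value is 50000 nM, with an expected range from 25000 nM to 100000 nM.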

Compound 4, half-maximal inhibitory concentration: 21800 nM
Compound 4: the middle estimate sits 2.3-fold (0.36 log units) above what was measured, and the stated range ends above it.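

In this assay, this position on the six-membered aromatic ring of carbon only now gives a readable step: bromo in place of chloro gives an at least 2.2-fold lower number from compound 3 to compound 4 (0.36 log units; beyond the scatter), and bromo in place of hydrogen gives an at least 2.2-fold lower number from compound 2 to compound 4 (0.36 log units; beyond the scatter), whereas the step for chloro in place of hydrogen cannot be read. Bromo is not sufficient by itself, since adding fluoro with bromo already present gives an at least 2.2-fold lower number from compound 1 to compound 4 (0.36 log units; beyond the scatter); among the compounds shown, only the combination of bromo and fluoro in compound 4 leaves the limit, and compound 2, with fluoro alone, and compound 1, with bromo alone, do not. Compound 4 is thus the only compound in the series with a number, and the other three stay at one shared limit: the limit of > 50000 nM in this assay, at which 3 of the 4 values shown sit.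

On these data alone, all three new steps are lower bounds, so their true sizes remain open, as does the size of any difference among the compounds still at the limit. Also open, as far as these compounds go, is whether iodo, methoxy or an amine at this aromatic carbon would keep, strengthen or lose the readable value seen with bromo.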